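The source may report more compounds than this note shows. Statements on the series, on what has been measured and on what is new or still open speak of the compounds shown alone.

In a functional assay on MOLT-4F cells (Homo sapiens) for antiproliferative activity (a higher number here means a weaker inhibitor of growth, a lower number a stronger inhibitor of growth), three compounds sharing one core have been measured: compound 1 `COCCCCCCCCCCC/C=C1\CC(CO)(COC(=O)C(C)(C)C)OC1=O` gives 2.38 ug/mL, compound 2 `CCCCCCCCC(O)CCCCCC/C=C1\CC(CO)(COC(=O)C(C)(C)C)OC1=O` gives 7.91 ug/mL and compound 3 `CCCCCOCCCCCCC/C=C1\CC(CO)(COC(=O)C(C)(C)C)OC1=O` gives 1.03 ug/mL. Compound 3 has the lowest number of the three and is the strongest growth inhibitor so far.

Compound 4 `CC(C)(C)C(=O)OCC1(CO)C/C(=C\CCCCCCCCCCCCCCC=O)C(=O)O1` has 7-formylheptyl in place of pentyloxy, on a saturated chain carbon, seven bonds along the chain from a double-bonded chain carbon: 7-formylheptyl in place of pentyloxy on a saturated chain carbon, seven bonds along the chain from a double-bonded chain carbon. For the measured compounds named here, no measured step makes this exact change. The closest evidence comes from the other chain changes: a 2.3-fold lower number from compound 1 to compound 3 (0.36 log units; beyond the scatter), a 3.3-fold higher number from compound 1 to compound 2 (0.52 log units; beyond the scatter) and a 7.7-fold lower number from compound 2 to compound 3 (0.89 log units; beyond the scatter). All three are modest, so a chain change of this kind has not yet produced a large step. The entering group resembles 1-hydroxynonyl in having no pentyloxy, and compound 2, which carries that group, has 7.91 ug/mL. A modest move away from compound 3 towards a higher number is therefore expected. The expected step is a 2.7-fold higher number from compound 3 to compound 4 (0.43 log units; beyond the scatter). Compound 4 is estimated at 2.8 ug/mL, with an expected range of 1 ug/mL to 8 ug/mL.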

Compound 4, concentration for 50% growth inhibition: > 10 ug/mL
Compound 4: no number, only a limit; the forecaster's own chance of this, stated with the estimate: 3%; at least 3.5-fold (0.55 log units) between middle value and limit.
By their numbers in this assay, from the lowest: compound 3; then compound 1; then compound 2. At a limit, above all of these: compound 4.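

In this assay compound 4 gives no number, only a limit: the limit of > 10 ug/mL in this assay, at which 1 of the 4 values shown sits. With 7-formylheptyl in place of pentyloxy, on a saturated chain carbon, seven bonds along the chain from a double-bonded chain carbon, the series shows an at least 9.7-fold higher number from compound 3 to compound 4 (0.98 log units; beyond the scatter) and an at least 4.2-fold higher number from compound 1 to compound 4 (0.62 log units; beyond the scatter), so this place in the chain can carry a change that takes a compound to a limit, which none of the earlier chain changes did. The remaining step, an at least 1.2-fold higher number from compound 2 to compound 4 (0.10 log units; that floor lies within the scatter), does not separate that pair.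

On these data alone, the true value of compound 4 stays open, and with it the full size of these steps. Also open, as far as these compounds go, is whether the formyl group or the chain length drives the result, a question that 7-carboxyheptyl or a shorter formyl-ended chain at the same place would address.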